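Swapping the amide aryl group on a weak cytotoxic analogue

The compounds below may be only part of what the source reports. "The series", "measured", "known", "first", "only" and "open" are said of these compounds alone.

In a functional assay on MDA-MB-231 cells (Homo sapiens) for cytotoxicity, read by MTT assay, with a stated time of 72 h (a lower number here means a stronger inhibitor, a higher number a weaker inhibitor), compound 2 `COc1ccc(NC(=O)CN2CCN(c3nnc(Cc4ccccc4)c4ccccc34)CC2)cc1OC` gives 32200 nM, the highest number among the three measured compounds. Compound 1 `O=C(CN1CCN(c2nnc(Cc3ccncc3)c3ccccc23)CC1)Nc1cccc(F)c1` gives 4.4 nM, and compound 3 `O=C(CN1CCN(c2nnc(Cc3ccncc3)c3ccccc23)CC1)Nc1cccc(Br)c1` gives 1.7 nM. Among the measured compounds shown here, the only measured step is modest: a 2.6-fold lower number from compound 1 to compound 3 (0.41 log units; beyond the scatter). Compound 4 `Cc1ccccc1NC(=O)CN1CCN(c2nnc(Cc3ccccc3)c3ccccc23)CC1` differs from compound 2 in one place: 2-methylphenyl in place of 3,4-dimethoxyphenyl on an amide-type nitrogen. For the measured compounds named here, no measured step matches this change, and compound 2 differs from compounds 1 and 3 in two places at once, so their wide gap cannot be credited to the aryl group alone. The change is therefore expected to give a loosely estimated step of a 5.4-fold lower number from compound 2 to compound 4 (0.73 log units; beyond the scatter). Compound 4 is estimated at 6000 nM, with a range from 600 nM to 40000 nM.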

Compound 4, half-maximal inhibitory concentration: 17300 nM
Compound 4: the middle estimate sits 2.9-fold (0.46 log units) below what was measured; measured number inside the range.
By their numbers in this assay, from the lowest: compound 3; then compound 1; then compounds 4 and 2 (each within the scatter of the next).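

On the core shared by compound 2 and compound 4, the aryl group on the amide-type nitrogen goes from 3,4-dimethoxyphenyl to 2-methylphenyl, giving a 1.9-fold lower number from compound 2 to compound 4 (0.27 log units; within the scatter) in this assay. At this position, then, the aryl group can lose its 2 hydrogen-bond acceptors and shrink from 10 heavy atoms to 7 without a change beyond the scatter.

From the compounds shown here alone, whether an amine or a carboxylic acid on this aryl ring would read the same remains open, as does the effect of this swap on the core of compound 1. No available evidence bears on this result.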